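A few compounds are considered here, and "the series" means these few. Any claim that something is new, unique, unknown or untested is made for them only; others in the source may bear on it.

Measured in a physicochemical assay for lipophilicity, at pH 7.4; on this read-out lower numbers stand for lower lipophilicity and higher numbers for higher lipophilicity:
- Compound 1 `CC(C)CN(C1CCc2ccc(F)cc21)S(=O)(=O)c1ccc2c(c1)C(=O)CC(C1CCOCC1)O2`: 4.03
- Compound 2 `CC(C)CN(c1cccc(F)c1)S(=O)(=O)c1ccc2c(c1)C(=O)CC(C1CCOCC1)O2`: 3.5

Within the data shown here, of the two compounds measured so far in this assay, compound 2 holds the lower number, at 3.5. The next compound, compound 3 `Cc1ccc(N(CC(C)C)S(=O)(=O)c2ccc3c(c2)C(=O)CC(C2CCOCC2)O3)c(C)c1`, has yet to be measured. It has 2,4-dimethylphenyl in place of 3-fluorophenyl on a sulfonamide nitrogen, and the counted difference is 2,4-dimethylphenyl in place of 3-fluorophenyl on a sulfonamide nitrogen.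

Among the measured compounds shown here, only one measured step bears on this change, and only indirectly. That step is a number 0.53 log units lower from compound 1 to compound 2 (beyond the scatter), and it also alters the group at this sulfonamide nitrogen, but 2,4-dimethylphenyl appears in neither measured compound. The data therefore offer no direct test of the new group. Its size still suggests that a change at this place can move the number beyond the scatter. A rise of similar modest size seems the likeliest outcome, although the direction is a judgement from the structural change alone.

The expected step is a number 0.45 log units higher from compound 2 to compound 3 (beyond the scatter). For compound 3 the estimate is 3.95, with an expected range from 3.55 to 4.35.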

Compound 3, distribution coefficient: 4.28
The estimate for compound 3 lay 0.33 log units below the measured number; measured number inside the range.
By their numbers in this assay, from the lowest: compound 2; then compounds 1 and 3 (each within the scatter of the next).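

In this assay, replacing 3-fluorophenyl with 2,4-dimethylphenyl on the sulfonamide nitrogen keeps one six-membered aromatic ring of carbon only, yet it gives a number 0.78 log units higher from compound 2 to compound 3 (beyond the scatter), so changing what that ring carries, with the ring itself kept, is enough to move the number at this place. The second comparison gives a number 0.25 log units higher from compound 1 to compound 3 (within the scatter), which means that 2,4-dimethylphenyl and 6-fluoro-2,3-dihydro-1H-inden-1-yl cannot be told apart on this read-out, and among these three compounds only compound 2, with its 3-fluorophenyl, stands clear of the other two. Nothing in the data shown explains the size of either step.

The fluorine leaves and both methyl groups enter in this single change, so the compounds shown do not separate the contribution of each, and a group such as 4-methylphenyl or 2-methylphenyl on the sulfonamide nitrogen would be needed to do so. They also leave open how this assay would read with a ring containing nitrogen at this place, such as pyridinyl, or with a plain phenyl carrying a carboxylic acid or an amine.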